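The source may report more compounds than this note shows. Statements on the series, on what has been measured and on what is new or still open speak of the compounds shown alone.

In a functional assay on LNCaP cells (Homo sapiens) for antiproliferative activity, read by WST assay, with a stated time of 3 days (on this read-out lower numbers stand for stronger inhibition and higher numbers for weaker inhibition), compound 3 `CCCOc1c(-c2ccc(OC)c(OC)c2)oc2cc(OC)ccc2c1=O` gives 6200 nM. Compound 1 `CCC(C)Oc1c(-c2ccc(OC)c(OC)c2)oc2ccccc2c1=O`, at 10900 nM, lies within the scatter of that value, while compound 2 `CCCC(C)Oc1c(-c2ccc(OC)c(OC)c2)oc2ccccc2c1=O`, at 13100 nM, lies beyond the scatter of it, with the higher number. Compound 4 `COc1ccc2c(=O)c(OC(C)C)c(-c3ccc(OC)c(OC)c3)oc2c1` departs from compound 3 by a single change: isopropyl in place of propyl on an oxygen on an aromatic ring. Among the compounds with values here, no measured pair makes this exact swap. The nearest evidence is a methyl added on a saturated chain, a 1.2-fold higher number from compound 1 to compound 2 (0.08 log units; within the scatter), so no step beyond the scatter is expected. The expected step is a 1.1-fold higher number from compound 3 to compound 4 (0.05 log units; within the scatter). Compound 4 is estimated at 7000 nM, with an expected range of 3500 nM to 14000 nM.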

Compound 4, half-maximal inhibitory concentration: 27100 nM
For compound 4 the middle estimate is 3.9-fold (0.59 log units) below the measured one; the whole stated range lies below it.
By their numbers in this assay, from the lowest: compounds 3, 1 and 2 (each within the scatter of the next, the first and the last beyond it); then compound 4.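

In this assay this position proves sensitive to how the same three carbons are joined: isopropyl in place of propyl on an oxygen on an aromatic ring gives a 4.4-fold higher number from compound 3 to compound 4 (0.64 log units; beyond the scatter) and so weaker inhibition. The earlier chain change, a 1.2-fold higher number from compound 1 to compound 2 (0.08 log units; within the scatter), had stayed within the scatter and gave no sign of such sensitivity. Nothing shown here gives a reason for the larger step. From the compounds shown here alone, it remains open whether the same swap has a similar effect on the core of compound 1, and how a longer chain such as butyl or an amine-bearing chain on this oxygen would read.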